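The compounds below may be only part of what the source reports. "The series", "measured", "known", "first", "only" and "open" are said of these compounds alone.

Measured compounds:
- Compound 1, `Cc1ccc(-c2c(C)nc(NC(=O)NC3CCOCC3)c(C)c2C(OC(C)(C)C)C(=O)O)cc1C`, in an ADME assay on MT4 cells (Homo sapiens) for cytotoxicity, read by MTT assay (a higher number here means that more compound is tolerated, a lower number that less compound is tolerated), compound 1 gives 29000 nM.
- Compound 2, `Cc1ccc(-c2c(C)nc(Nc3nc4ccccc4n3C)c(C)c2C(OC(C)(C)C)C(=O)O)cc1C`, in this assay compound 2 gives 14000 nM.

Within the data shown here, compound 2 stands at the lower of the two numbers, with compound 1 as its only neighbour, and the single measured step between them, a 2.1-fold lower number from compound 1 to compound 2 (0.32 log units; beyond the scatter), sets the whole of what is known about this series in this assay. Compound 3, `Cc1ccc(-c2c(C)nc(NC(=O)Nc3ccccc3)c(C)c2C(OC(C)(C)C)C(=O)O)cc1C`, has not been measured in this assay; it differs from compound 2 in one place, (phenylcarbamoyl in place of 1-methyl-1H-benzimidazol-2-yl on a nitrogen on an aromatic ring). Among the measured compounds shown here, the one step that bears on this change is the same step read in reverse: a carbamoyl group on the ring nitrogen was exchanged for the benzimidazolyl group, and the number fell. Returning to a carbamoyl group, now carrying a phenyl instead of the oxan-4-yl, is therefore expected to move the number back up by a modest amount, though the phenyl for oxanyl part of the change has no measured counterpart, so the expected step of a 1.6-fold higher number from compound 2 to compound 3 (0.20 log units; within the scatter) carries a wide range. Compound 3 is thus estimated at 22000 nM, between 10000 nM and 50000 nM.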

Compound 3, half-maximal cytotoxic concentration: 9900 nM
Estimate against measurement, compound 3: 2.2-fold (0.35 log units) above; the measured number lies below the stated range.
By their numbers in this assay, from the lowest: compounds 3 and 2 (each within the scatter of the next); then compound 1.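

In this assay, the exchange on a nitrogen on an aromatic ring gives a 1.4-fold lower number from compound 2 to compound 3 (0.15 log units; within the scatter), so a phenylcarbamoyl group and a 1-methyl-1H-benzimidazol-2-yl group cannot be told apart here, even though the two groups differ in their rings and in their counts of hydrogen-bond donors and acceptors. The other new comparison keeps the carbamoyl group and changes only what it carries: phenyl in place of oxan-4-yl on an amide-type nitrogen gives a 2.9-fold lower number from compound 1 to compound 3 (0.47 log units; beyond the scatter), which shows that the presence of a carbamoyl group does not by itself set the number, and that the group on its far side matters in this pair. No measurement is available that would account for either result.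

The compounds shown leave open whether a cyclohexyl group on the carbamoyl would give a number nearer that of compound 1 or that of compound 3, which would help separate the part played by the ring oxygen of oxan-4-yl from that of the aromatic ring of phenyl. They also leave open whether a pyridin-3-yl group in place of the phenyl would keep the number of compound 3.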